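Swapping the Aryl Ring on Sulfur: Estimating Compound 4

The source may report more compounds than this note shows. Statements on the series, on what has been measured and on what is new or still open speak of the compounds shown alone.

Compound 1 `Sc1nnc(-c2ccc3c(c2)OCCO3)n1-c1ccccc1` gives 47000 nM in a functional assay on BGC-823 cells (Homo sapiens) for antiproliferative activity, read by MTT assay, with a stated time of 24 h; on this read-out lower numbers stand for stronger inhibition and higher numbers for weaker inhibition.
Compound 2 `COc1cccc(CSc2nnc(-c3ccc4c(c3)OCCO4)n2-c2ccccc2)c1` reaches only a limit of the assay, > 100000 nM.
Compound 3 `Cc1ccc(CSc2nnc(-c3ccc4c(c3)OCCO4)n2-c2ccccc2)cc1` gives 44300 nM.

Compound 3 holds the lowest of the two numbers, but its nearest neighbour, compound 1, sits within the scatter of it, so no order between these two can be claimed. Compound 4 `Fc1ccc(CSc2nnc(-c3ccc4c(c3)OCCO4)n2-c2ccccc2)c(F)c1` has not yet been measured; it differs from compound 3 in one place: 2,4-difluorophenyl in place of 4-methylphenyl on a saturated chain carbon bound to a sulfur.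

Among the compounds with values here, three measured steps bear on this change. The step at the same place, an at least 2.2-fold lower number from compound 2 to compound 3 (0.35 log units; beyond the scatter), shows that the aryl ring on this chain carbon can shift the number beyond the scatter, with the limit of > 100000 nM in this assay, at which 1 of the 3 values shown sits, setting the size. The steps from the bare sulfur, a 1.1-fold lower number from compound 1 to compound 3 (0.03 log units; within the scatter) and an at least 2.1-fold higher number from compound 1 to compound 2 (0.32 log units; beyond the scatter), show that attaching a benzyl group gives at most a modest move. On that basis no step beyond the scatter is expected from compound 3 to compound 4: a 1.1-fold higher number from compound 3 to compound 4 (0.05 log units; within the scatter). Compound 4 is therefore estimated at 50000 nM in this assay, within 20000 nM to 120000 nM.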

Compound 4, half-maximal inhibitory concentration: > 100000 nM
Compound 4: no number, only a limit; the forecaster's own chance of this, stated with the estimate: 25%; middle value at least 2.0-fold (0.30 log units) from the limit.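

The change shows an at least 2.2-fold higher number from compound 3 to compound 4 (0.35 log units; beyond the scatter), so compound 4 is now a second aryl ring on this chain carbon, after compound 2, that stands apart from the 4-methylphenyl ring of compound 3. Within the data shown here, it also shows an at least 2.1-fold higher number from compound 1 to compound 4 (0.32 log units; beyond the scatter), which leaves compound 3 as the one benzyl compound against the pattern that a benzyl group on the sulfur raises the number in this assay. The step between compound 2 and compound 4 cannot be read, and the steps to compound 4 are bounds rather than sizes, since its value is a limit of the assay: the limit of > 100000 nM in this assay, at which 2 of the 4 values shown sit.

From the compounds shown here alone, how far compound 2 and compound 4 differ from each other stays open. Going by these compounds, it is also open whether an unsubstituted benzyl group, a longer chain such as 2-phenylethyl, or an amine on the ring would stay near compound 3.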